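Cytotoxicity on Vero Cells: Toward a Naphthyl Analog

The source may report more compounds than this note shows. Statements on the series, on what has been measured and on what is new or still open speak of the compounds shown alone.

Measured compounds:
compound 1 `COc1ccc(COc2ccc3c(c2)[C@@H](O)CN(C)C3)cc1`: > 50000 nM
compound 2 `COCCOCOc1ccc2c(c1)[C@@H](O)CN(C)C2`: > 50000 nM
compound 3 `CN1Cc2ccc(OCc3cccc(Br)c3)cc2[C@@H](O)C1`: 60300 nM

In an ADME assay on Vero cells (Chlorocebus sabaeus) for cytotoxicity, read by sulforhodamine B assay, with a stated time of 72 h (a lower number here means a stronger inhibitor, a higher number a weaker inhibitor), compound 1 gives > 50000 nM, which is a limit of the assay and not a number. Compound 2 likewise gives > 50000 nM, again a limit. Compound 3 gives 60300 nM, a weak effect. The step that the limit leaves unreadable from compound 2 to compound 3 cannot be sized because of the limit of > 50000 nM in this assay, at which 2 of the 3 values shown sit.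

Compound 4 `CN1Cc2ccc(OCc3ccc(-c4ccc5ccccc5c4)cc3)cc2[C@@H](O)C1` differs from compound 1 by naphthalen-2-yl in place of methoxy on an aromatic carbon. Among the compounds with values here, no measured step mirrors this change, and the one measured step is unreadable, so it gives no guide to direction or size. All three measured compounds sit at or near the limit, so compound 4 is expected to remain a weak inhibitor, with the step of an at least 1.2-fold lower number from compound 1 to compound 4 (0.09 log units; that floor lies within the scatter) estimated to stay close to the scatter. Compound 4 is therefore estimated at 40000 nM, between 15000 nM and 100000 nM.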

Compound 4, half-maximal inhibitory concentration: 310 nM
For compound 4 the middle estimate is 130-fold (2.11 log units) above the measured one; measured number below the stated range.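

In this assay, the aromatic carbon para to a large group turns out to matter: naphthalen-2-yl in place of methoxy gives an at least 160-fold lower number from compound 1 to compound 4 (2.20 log units; beyond the scatter). Within the data shown here, the only earlier step cannot be read, so this is the first sign that a change on the shared core can move the result beyond the scatter. Compound 1 gives > 50000 nM, which is a limit of the assay and not a number, so the step marks only a floor. As far as these compounds go, what a single phenyl ring or an amine on this same carbon would give remains open.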